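Dropping a chloro from a benzoxazole sulfonamide: tolerance expected unchanged

This account rests on a few compounds, and the source may have more. Where it says the series, first, only, none or still open, it means among the compounds named here.

Three compounds sharing one core were tested in an ADME assay on HEK293 cells (Homo sapiens) for cytotoxicity, read by resazurin assay, with a stated time of 48 h; a higher number here means that more compound is tolerated, a lower number that less compound is tolerated. Compound 1 `O=S(=O)(Nc1ccc2oc(-c3ccccc3)nc2c1)c1ccc(Cl)c(Cl)c1` gives 71000 nM. Compound 2 `COc1ccc(Cl)cc1S(=O)(=O)Nc1ccc(-c2nc3ccccc3o2)cc1` gives 75000 nM. Compound 3 `O=S(=O)(Nc1ccc(-c2nc3ccccc3o2)cc1)c1ccc(C(F)(F)F)cc1` gives 94000 nM. The value of compound 2 lies alongside those of compound 1 and compound 3, and all three numbers sit within the usual scatter of one another, so none stands apart.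

Compound 4 `COc1ccccc1S(=O)(=O)Nc1ccc(-c2nc3ccccc3o2)cc1` differs from compound 2 in one place: hydrogen in place of chloro on an aromatic carbon. Cut one bond further out, 5-chloro-2-methoxyphenyl becomes 2-methoxyphenyl. Within the data shown here, with no measured step of this kind to lean on, the expected step of a 1.1-fold higher number from compound 2 to compound 4 (0.05 log units; within the scatter) in this assay is small and within the scatter. Compound 4 is therefore estimated at 85000 nM, with a range from 45000 nM to 160000 nM.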

Compound 4, half-maximal cytotoxic concentration: > 100000 nM
Compound 4 gave a limit, no number (the forecaster's own chance of this, stated with the estimate: 25%); middle value at least 1.1-fold (0.07 log units) away from the limit.
By their numbers in this assay, from the lowest: compounds 1, 2 and 3 (each within the scatter of the next). At a limit, above all of these: compound 4.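

Hydrogen in place of chloro gives the first single-place comparison in this assay: an at least 1.3-fold higher number from compound 2 to compound 4 (0.12 log units; that floor lies within the scatter). Compound 4 stands at a limit, not a number: the limit of > 100000 nM in this assay, at which 1 of the 4 values shown sits. Losing the chloro from this position of the 5-chloro-2-methoxyphenyl group therefore brings no fall in tolerance, but the true size of the step cannot be read, and its floor lies within the scatter.

Open, as far as these compounds go, is how an amine or a carboxylic acid at this same position would behave. Also open, from the compounds shown here alone, is what removing the methoxy group would do.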